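The compounds below may be only part of what the source reports. "The series", "measured", "known", "first", "only" and "open" are said of these compounds alone.

Compound 1 `COc1ccccc1-c1c(C)nn(-c2nc(-c3ccc(Cl)c(Cl)c3)c(SC(C)C)s2)c1C(=O)O` gives 14700 nM
Compound 2 `COC(=O)c1c(Cc2ccccc2[N+](=O)[O-])c(C)nn1-c1nc(-c2ccc(Cl)c(Cl)c2)c(SC(C)C)s1` gives 93000 nM
Compound 3 `Cc1c(-c2cc(Cl)cc(Cl)c2)c(C(=O)O)nn1-c1nc(-c2cc(Cl)ccc2F)c(SC(C)C)s1` gives 4800 nM

All three were tested in a functional assay on BJAB cells (Homo sapiens) for antiproliferative activity, with a stated time of 4 days; on this read-out higher numbers stand for an effect only at larger amounts of compound and lower numbers for an effect already at smaller amounts. Compound 1 stands second highest of the three numbers: compound 3 sits lower and compound 2 sits higher, and both gaps lie beyond the usual scatter. Compound 4 `Cc1nn(-c2nc(-c3ccc(Cl)c(Cl)c3)c(SC(C)C)s2)c(C(=O)O)c1-c1cccc(F)c1` has not been measured yet. It differs from compound 1 in one place: 3-fluorophenyl in place of 2-methoxyphenyl on an aromatic carbon. Among the measured compounds shown here, no pair of measured compounds shows this change on its own, so the expectation rests on the change itself and on the spread of the three numbers. A small move toward lower numbers is expected, a 1.6-fold lower number from compound 1 to compound 4 (0.21 log units; within the scatter), probably still within the scatter. For compound 4 the estimate in this assay is 9000 nM, with a range from 3500 nM to 25000 nM.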

Compound 4, half-maximal effective concentration: 900 nM
Estimate against measurement, compound 4: 10-fold (1.00 log units) above; the whole stated range lies above it.
By their numbers in this assay, from the lowest: compound 4; then compound 3; then compound 1; then compound 2.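

In this assay, 3-fluorophenyl in place of 2-methoxyphenyl gives a 16-fold lower number from compound 1 to compound 4 (1.21 log units; beyond the scatter) and this step lies beyond the scatter. Among the compounds shown here, it is the first step here with only one place changed, and it shows that the aromatic group on this carbon, next to the ring atom that bears a carboxy group, can alone move the number by a large amount. No measured evidence here explains the size of this step. Still open, going by these compounds, is whether the change follows from the fluorine, from the loss of the methoxy group, or from where each sits on the phenyl ring. On these data alone, what a phenyl ring carrying an amine would give on this carbon is also open.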